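The source may report more compounds than this note shows. Statements on the series, on what has been measured and on what is new or still open speak of the compounds shown alone.

Compound 3 `CCN(Cc1ccccc1)C(=O)C1CCN(S(=O)(=O)c2ccc3occc3c2)CC1` gives 80% in a functional assay on CHO cells for positive allosteric modulation of muscarinic acetylcholine receptor M5 (Homo sapiens), read by calcium flux (a higher number here means a larger maximal response, a lower number a smaller maximal response), where it stands second highest of the three measured compounds. Compound 1 `CCN(Cc1ccccc1)C(=O)C1CCN(S(=O)(=O)c2ccc(OC)cc2)CC1` gives 84%, and compound 2 `CCN(Cc1ccccc1)C(=O)C1CCN(S(=O)(=O)c2cccc(OC)c2)CC1` gives 77%. The steps of a number 4 percentage points lower from compound 1 to compound 3 (within the scatter) and a number 3 percentage points higher from compound 2 to compound 3 (within the scatter) both lie within the scatter, as does a number 7 percentage points lower from compound 1 to compound 2 (within the scatter). Compound 4 `CCN(Cc1ccccc1)C(=O)C1CCN(S(=O)(=O)c2ccc3[nH]ncc3c2)CC1` differs from compound 3 in one place: 1H-indazol-5-yl in place of 1-benzofuran-5-yl on a sulfonyl sulfur. Every exchange of the group on the sulfonyl sulfur seen so far has moved the maximal response only within the scatter, so the step of a number 2 percentage points lower from compound 3 to compound 4 (within the scatter) is expected to stay within the scatter as well. Compound 4 is therefore estimated at 78%, with a range from 62% to 92%.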

Compound 4, largest response reached (reported as percent of maximum), in percent of the reference or control that the assay uses: 86%
Estimate against measurement, compound 4: 8 percentage points below, and the stated range covers the measured number.
By their numbers in this assay, from the lowest: compounds 2, 3, 1 and 4 (each within the scatter of the next).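

In this assay, 1H-indazol-5-yl brings 1 hydrogen-bond donor where 1-benzofuran-5-yl has 0, yet the result is a step of a number 6 percentage points higher from compound 3 to compound 4 (within the scatter) and the other two steps are a number 9 percentage points higher from compound 2 to compound 4 (within the scatter) and a number 2 percentage points higher from compound 1 to compound 4 (within the scatter) in the same read-out. So on this sulfonyl sulfur, adding a hydrogen-bond donor does not separate compound 4 from the other three compounds. No measurement shown explains this result.
On these data alone, whether an amine, a carboxylic acid or a longer alkyl chain on the sulfonyl sulfur would keep this maximal response stays open. Changes elsewhere on the shared core also remain untested in the compounds shown here.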